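The source may report more compounds than this note shows. Statements on the series, on what has been measured and on what is new or still open speak of the compounds shown alone.

Going by the values given here, compound 2 `Cc1ccnc(/C(N)=N/NC(=S)N2CCOCC2)c1` sits lowest of the three compounds measured so far in a functional assay on MCF7 cells (Homo sapiens) for cytotoxicity, read by MTT assay, with a stated time of 72 h, tested at 10 uM; on this read-out higher numbers stand for more inhibition of growth at the one concentration tested and lower numbers for less inhibition of growth: compound 2 gives 6.86%, whereas compound 1 `N/C(=N\NC(=S)N1CCOCC1)c1ccccn1` gives 66.7% and compound 3 `N/C(=N\NC(=S)N1CCSCC1)c1ccc(F)cn1` gives 38.1%. Among the compounds with values here, the only single-place step among them, a number 59.8 percentage points lower from compound 1 to compound 2 (beyond the scatter), consists of a methyl in place of hydrogen on an aromatic carbon, and it is large. Compound 4 `Cc1ccnc(/C(N)=N/NC(=S)N2CCCC2)c1` differs from compound 2 elsewhere: pyrrolidin-1-yl in place of morpholin-4-yl on a thiocarbonyl carbon. Within the data shown here, no measured pair isolates this exchange at the thiocarbonyl carbon; compound 3 carries a different six-membered ring there but also a fluorine on the aromatic ring, so its gap to compound 2 cannot be assigned to one change. Among the measured compounds shown here, with no directly bearing step, the author expects the change from compound 2 to compound 4 to stay within the scatter, a number 5.1 percentage points higher from compound 2 to compound 4 (within the scatter), with a wide margin on the upper side. Compound 4 is therefore estimated at 12%, between 0% and 40% in this assay.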

Compound 4, percent growth inhibition at one concentration: 63.6%
Compound 4: middle estimate off by 51.6 percentage points, on the low side; the measured number lies above the stated range.
By their numbers in this assay, from the lowest: compound 2; then compound 3; then compounds 4 and 1 (each within the scatter of the next).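

In this assay, the exchange of morpholin-4-yl for pyrrolidin-1-yl on the thiocarbonyl carbon gives a number 56.7 percentage points higher from compound 2 to compound 4 (beyond the scatter) and is large, so this position strongly affects the read-out in the methyl-bearing series. The methyl step, a number 59.8 percentage points lower from compound 1 to compound 2 (beyond the scatter), had suggested that the methyl was enough to bring growth inhibition down, but the new step shows that the low number of compound 2 depends on the group at the thiocarbonyl carbon as well. Nothing available explains why this exchange has so large an effect.

Still open, on these data alone, is whether pyrrolidin-1-yl has the same effect on the core of compound 1, which lacks the methyl. Also open, as far as these compounds go, is whether ring size or the ring oxygen matters, a question that piperidin-1-yl at the same place could help to separate.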